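This account rests on a few compounds, and the source may have more. Where it says the series, first, only, none or still open, it means among the compounds named here.

Measured so far in an ADME assay on BEAS-2B cells (Homo sapiens) for cytotoxicity, read by MTT assay, with a stated time of 72 h; on this read-out higher numbers stand for weaker inhibition of growth and lower numbers for stronger inhibition of growth:
Compound 1 `[SeH]c1nc(NCc2ccccc2)c2ccccc2n1` gives > 100000 nM, which is a limit of the assay and not a number.
Compound 2 `CSc1ccc(CNc2nc([Se]C)nc3ccccc23)cc1` gives 78500 nM.
Compound 3 `CSc1nc(NCc2ccccc2)c2ccccc2n1` gives 88200 nM.

Compound 3 holds the higher of the two numbers, yet compound 2 sits within the scatter of it, so the two cannot be ordered. For the measured compounds named here, the only single-change step measured, an at least 1.1-fold lower number from compound 1 to compound 3 (0.05 log units; that floor lies within the scatter), likewise lies within the scatter. Compound 4 `C[Se]c1nc(NCc2ccccc2)c2ccccc2n1` carries a group of 2 heavy atoms (1 carbon, 1 selenium; no ring) in place of a group of 2 heavy atoms (1 carbon, 1 sulfur; no ring), on an aromatic carbon. Compound 2 carries the same entering group together with a further change, and its value differs from that of compound 3 only within the scatter. Nothing here points to a shift beyond the scatter, so the step of a 1.0-fold lower number from compound 3 to compound 4 (0.02 log units; within the scatter) is expected to be small. Compound 4 is estimated at 85000 nM, plausibly anywhere from 40000 nM to 180000 nM.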

Compound 4, concentration for total growth inhibition: 37000 nM
Compound 4: middle estimate off by 2.3-fold (0.36 log units), on the high side, outside the stated range (below it).
By their numbers in this assay, from the lowest: compound 4; then compounds 2 and 3 (each within the scatter of the next). At a limit, above all of these: compound 1.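

Methyl on selenium in place of methylsulfanyl gives a 2.4-fold lower number from compound 3 to compound 4 (0.38 log units; beyond the scatter) on the aromatic carbon between two ring nitrogen atoms and is the first step at this position to clear the scatter, towards stronger inhibition of growth. Hydrogen in place of the second methylsulfanyl gives a 2.1-fold lower number from compound 2 to compound 4 (0.33 log units; beyond the scatter) in the same direction, so the selenium gain shows up without that group. Methyl in place of hydrogen on selenium gives an at least 2.7-fold lower number from compound 1 to compound 4 (0.43 log units; beyond the scatter) as a floor only, and compound 1 stands at a limit, not a number: the limit of > 100000 nM in this assay, at which 1 of the 4 values shown sits.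

As far as these compounds go, whether a longer chain such as ethyl on the selenium would follow compound 4 stays open. So does the effect of an amine at this carbon.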